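A few compounds are considered here, and "the series" means these few. Any claim that something is new, unique, unknown or untested is made for them only; others in the source may bear on it.

Measured compounds: compound 1 `O=c1c2cc([N+](=O)[O-])cnc2sn1-c1ccc(Br)cc1`, giving 860 nM in an assay for inhibition of histone acetyltransferase KAT2B (Homo sapiens), read by fluorescence; on this read-out lower numbers stand for stronger inhibition and higher numbers for weaker inhibition; compound 2 `O=c1c2cccnc2sn1-c1ccc(Br)cc1`, for which compound 2 has "not determined" (no result reported) in this assay, that is, no result was reported.

Within the data shown here, compound 1 carries the only number in this assay, so it alone sets the scale. Compound 3 `COc1ccc(-n2sc3ncc([N+](=O)[O-])cc3c2=O)cc1` differs from compound 1 in one place: methoxy in place of bromo on an aromatic carbon. Among the measured compounds shown here, no step between two measured compounds is available, so the size of this change cannot be read from the data. The step of a 1.4-fold higher number from compound 1 to compound 3 (0.14 log units; within the scatter) is expected to be small, at most a mild loss beyond the scatter. Compound 3 is therefore expected to give about 1200 nM, within 400 nM to 3600 nM.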

Compound 3, half-maximal inhibitory concentration: 1830 nM
The estimate for compound 3 lay 1.5-fold (0.18 log units) below the measured number; the measured number falls inside the stated range.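

In this assay, among these compounds, replacing bromo with methoxy on this aromatic carbon, para to a large group, gives a 2.1-fold higher number from compound 1 to compound 3 (0.33 log units; beyond the scatter), the first measured change at this position. It shows that the number responds to the group placed here, but only modestly, and that inhibition survives the swap. Nothing measured here explains the shift.

Steps involving compound 2 cannot be read, as it has no reported result, so the contribution of the nitro group remains open. Also open, on these data alone, is how an amine, a carboxylic acid or a longer chain would fare at this position.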